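Working notes: fluoro to trifluoromethyl in the series

This account rests on a few compounds, and the source may have more. Where it says the series, first, only, none or still open, it means among the compounds named here.

Values in an ADME assay on HeLa cells (Homo sapiens) for cytotoxicity, read by crystal violet staining, with a stated time of 72 h; on this read-out lower numbers stand for higher toxicity in this test and higher numbers for lower toxicity in this test:
- compound 1 `CCOC(=O)c1cc(CCCOc2ccc(-c3noc(C(F)(F)F)n3)cc2C(F)(F)F)on1` gives 28400 nM
- compound 2 `CN(C)C(=O)c1cc(CCCOc2ccc(-c3noc(C(F)(F)F)n3)cc2[N+](=O)[O-])on1` gives 22500 nM
- compound 3 `CN(C)C(=O)c1cc(CCCOc2ccc(-c3noc(C(F)(F)F)n3)cc2F)on1` gives 20200 nM

Compound 3 stands within the scatter of both other compounds, so these numbers do not separate the three. The next step leads to compound 4 `CN(C)C(=O)c1cc(CCCOc2ccc(-c3noc(C(F)(F)F)n3)cc2C(F)(F)F)on1`, with trifluoromethyl in place of fluoro on an aromatic carbon.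

One measured step changes the group on that same carbon, namely a 1.1-fold lower number from compound 2 to compound 3 (0.05 log units; within the scatter), and it gives no measurable shift. Compound 1 already carries trifluoromethyl there, with 28400 nM as its value, though it differs from compound 4 elsewhere. No step beyond the scatter is therefore expected in this assay, in either direction. The expected change is a 1.2-fold higher number from compound 3 to compound 4 (0.07 log units; within the scatter) and no more. For compound 4 the estimate is 24000 nM, with an expected range from 12000 nM to 48000 nM.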

Compound 4, half-maximal cytotoxic concentration: 19200 nM
Estimate against measurement, compound 4: 1.3-fold (0.10 log units) above; measured number inside the range.
By their numbers in this assay, from the lowest: compounds 4, 3, 2 and 1 (each within the scatter of the next).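

In this assay, trifluoromethyl on this aromatic carbon, ortho to a large group, cannot be told apart from fluoro (a 1.1-fold lower number from compound 3 to compound 4 (0.02 log units; within the scatter)) or from nitro (a 1.2-fold lower number from compound 2 to compound 4 (0.07 log units; within the scatter)), so the three groups now compared on the dimethylamide give no measurable shift. Compound 4 also gives the first single-place read at the carbonyl carbon: with trifluoromethyl held, dimethylamino in place of ethoxy (a 1.5-fold lower number from compound 1 to compound 4 (0.17 log units; within the scatter)) likewise produces no shift beyond the scatter. No measurement is available that bears on why these steps stay so small.

As far as these compounds go, whether an amine or a carboxylic acid on that aromatic carbon would also stay within the scatter remains open. The carbonyl change rests on one pair, so a primary amide or a carboxylic acid at that carbonyl carbon is also an open question.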